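The source may hold more compounds than are shown below. What is called first, only, known or untested is meant among the compounds shown, and "the series" means these compounds.

Measured compounds:
compound 1 `CCC(=O)Nc1sc2c(c1C#N)CCCC2` gives 12000 nM in a functional assay on RKE cells for antagonist activity at Vasoactive intestinal polypeptide receptor 1 (Rattus norvegicus), read by HTRF and cAMP accumulation, with stated times of 10 min and 30 min; a lower number here means a stronger inhibitor, a higher number a weaker inhibitor.
compound 2 `CSc1cccc(-c2cc(C(C)(C)C)cc(C(C)C)c2CO)c1` gives 170 nM in this assay.

Going by the values given here, of the two numbers in this assay, compound 1 stands highest; its only neighbour, compound 2, lies below it by a gap beyond the scatter, so compound 1 is the weaker inhibitor of the pair. Compound 3 `CC(C)CC(=O)Nc1sc2c(c1C#N)CCCC2` shares the core of compound 1 and differs from it in one place: isopropyl in place of methyl on a saturated chain carbon bound to a carbonyl carbon. Among the compounds with values here, no step between measured compounds covers this change, and compound 2 rests on a different framework, so the gap between compound 2 and compound 1 gives no guide to it. With nothing measured to lean on, the expectation for this step is a small one, most likely within the scatter, with a slight lean toward a lower number. Compound 3 is therefore expected to give about 9000 nM in this assay, within a range from 2500 nM to 30000 nM. That estimate means an expected step of a 1.3-fold lower number from compound 1 to compound 3 (0.12 log units; within the scatter).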

Compound 3, half-maximal inhibitory concentration: 1900 nM
Compound 3: the middle estimate sits 4.7-fold (0.68 log units) above what was measured, outside the stated range (below it).
By their numbers in this assay, from the lowest: compound 2; then compound 3; then compound 1.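

In this assay, going by these compounds alone, the position on the saturated chain carbon bound to a carbonyl carbon proves sensitive to the group it carries: isopropyl in place of methyl gives a 6.3-fold lower number from compound 1 to compound 3 (0.80 log units; beyond the scatter), a step beyond the scatter, where the earlier compounds offered no step at all on this core. Methyl and isopropyl both consist of carbon and hydrogen alone, with no ring, no hydrogen-bond donor or acceptor and no net charge, so a change confined to a plain carbon group is enough to move the number on the core of compound 1. Nothing measured here bears on what lies behind this step.

Going by these compounds, a single step gives only one direction at this place, so it remains open whether a tert-butyl group, a longer chain or a cyclohexyl ring would continue the fall in the number, and how an amine or a carboxylic acid would fare there. Within the data shown here, compound 2 rests on a different framework and is joined to this pair by no step, so how its features relate to this change also stays open.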